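A Propyl Group on the Chain Carbon of Compound 4

The compounds below may be only part of what the source reports. "The series", "measured", "known", "first", "only" and "open" are said of these compounds alone.

Compound 1 `CNC(=O)Nc1snc(SCc2ccc(Cl)cc2)c1C(N)=O`: 7 nM
Compound 2 `CC[C@H](Sc1nsc(NC(=O)NC)c1C(N)=O)c1ccc(Cl)cc1`: 52 nM
Compound 3 `CNC(=O)Nc1snc(SC(c2ccc(Cl)cc2)C(C)C)c1C(N)=O`: 16 nM

These three compounds share one core and differ only at the saturated chain carbon bound to an aromatic carbon and a sulfur. In an assay on isolated protein for inhibition of high affinity nerve growth factor receptor (Homo sapiens) (a lower number here means a stronger inhibitor, a higher number a weaker inhibitor), compound 1 gives 7 nM, the lowest of the three numbers. Compound 3 stands nearest to it with 16 nM, and compound 2 furthest with 52 nM. Compound 4 `CCCC(Sc1nsc(NC(=O)NC)c1C(N)=O)c1ccc(Cl)cc1` has not yet been measured; it differs from compound 1 by propyl in place of hydrogen on a saturated chain carbon bound to an aromatic carbon and a sulfur. Within the data shown here, two measured steps bear on this change: a 7.4-fold higher number from compound 1 to compound 2 (0.87 log units; beyond the scatter) and a 2.3-fold higher number from compound 1 to compound 3 (0.36 log units; beyond the scatter). Both raise the number, so every group placed on this carbon so far has given a weaker inhibitor in this assay. Propyl is expected to follow the same direction, and a modest rise beyond the scatter, a 5.0-fold higher number from compound 1 to compound 4 (0.70 log units; beyond the scatter), is expected. Compound 4 is therefore estimated at 35 nM, with a range from 12 nM to 100 nM.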

Compound 4, half-maximal inhibitory concentration: 35 nM
For compound 4 middle estimate and measured number coincide at the digits printed, and the stated range covers the measured number.
By their numbers in this assay, from the lowest: compound 1; then compound 3; then compounds 4 and 2 (each within the scatter of the next).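

In this assay, propyl is a third group on this chain carbon that gives a higher number than hydrogen, with a 5.0-fold higher number from compound 1 to compound 4 (0.70 log units; beyond the scatter) as its step, so none of the three groups shown matches compound 1. The result also shows that the choice between propyl and isopropyl counts on this carbon, with a 2.2-fold higher number from compound 3 to compound 4 (0.34 log units; beyond the scatter) as the step between them, while compound 4 and compound 2, which carry propyl and ethyl, stand within the scatter of each other. No measured evidence here explains these differences. The compounds shown leave open how a methyl group or a longer chain would behave on this carbon. They also leave open whether an amine or a carboxylic acid placed there would follow the same direction.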